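The source may report more compounds than this note shows. Statements on the series, on what has been measured and on what is new or still open speak of the compounds shown alone.

Among the measured compounds shown here, in a functional assay on Jurkat cells (Homo sapiens) for inhibition, read by CCK-8 assay, with a stated time of 48 h (on this read-out lower numbers stand for stronger inhibition of growth and higher numbers for weaker inhibition of growth), compound 1 (`CC(C)c1cccc(Nc2nc(Nc3ccc(N4CCN(C)CC4)cn3)ncc2Cl)c1`) gives 12300 nM, the only number available so far. For compound 2 (`CN1CCN(c2ccc(Nc3ncc(Cl)c(Nc4ccc(C(C)(C)C)cc4)n3)nc2)CC1`) the result reads "not determined" (no result reported), so compound 2 has no place on the scale and cannot be ranked against compound 1. Compound 3 (`COc1ccc(Nc2nc(Nc3ccc(N4CCN(C)CC4)cn3)ncc2Cl)cc1`) has not yet been measured. For the measured compounds named here, the single structural change leading to it is methoxy in place of tert-butyl on an aromatic carbon, para to a large group. Going by the values given here, no measured step exists to show how much such a change matters, and compound 2 offers no number to start from. The expectation is therefore a step of no size beyond the usual scatter, in either direction, from the level of compound 1 at 12300 nM. In this assay, compound 3 is expected to give about 9000 nM, with an estimated range of 3000 nM to 25000 nM.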

Compound 3, concentration for 50% growth inhibition: 11200 nM
Compound 3: the middle estimate sits 1.2-fold (0.09 log units) below what was measured; low and high end bracket the measured number.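

In this assay, among the compounds shown here, the first readable step at this position is a swap of 3-isopropylphenyl for 4-methoxyphenyl, which gives a 1.1-fold lower number from compound 1 to compound 3 (0.04 log units; within the scatter) and shows that this change of group and of its place on the ring leaves the two compounds level with each other. The step between compound 2 and compound 3 cannot be read, as compound 2 has no number. No supporting measurement bears on why compound 1 and compound 3 read alike.

On these data alone, with the group and its place differing together, the effect of each alone stays open. Also open, as far as these compounds go, is whether an amine or a carboxylic acid on this six-membered aromatic ring would give a step beyond the scatter.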